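Carbamoyl for hydroxymethyl on the aryl tail of an oxazolidinone

A few compounds are considered here, and "the series" means these few. Any claim that something is new, unique, unknown or untested is made for them only; others in the source may bear on it.

Measured compounds in an assay on HEK293 cells for inhibition of N-acylethanolamine-hydrolyzing acid amidase (Rattus norvegicus), read by LC-MS, with a stated time of 30 min; a lower number here means a stronger inhibitor, a higher number a weaker inhibitor:
compound 1 `O=C(CCCCCc1ccc(Cl)cc1)N1CCOC1=O` gives 4600 nM
compound 2 `O=C(CCCCCc1ccc(O)cc1)N1CCOC1=O` gives 61 nM
compound 3 `O=C(CCCCCc1ccc(CO)cc1)N1CCOC1=O` gives 190 nM

Compound 3 stands second of the three numbers. Its nearest neighbour is compound 2, reached by the step of a 3.1-fold higher number from compound 2 to compound 3 (0.49 log units; beyond the scatter), a modest gap that still lies beyond the scatter. Its furthest neighbour is compound 1, and the step of a 24-fold lower number from compound 1 to compound 3 (1.38 log units; beyond the scatter) is large. The related step of a 75-fold lower number from compound 1 to compound 2 (1.88 log units; beyond the scatter) is the largest seen, so both oxygen-bearing groups at this position leave chloro far behind.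

The next compound is compound 4 `NC(=O)c1ccc(CCCCCC(=O)N2CCOC2=O)cc1`. It arises from compound 3 by carbamoyl in place of hydroxymethyl on an aromatic carbon. The measured steps bearing on this change are those at the same aromatic carbon: the two large moves away from chloro and the modest move from hydroxy to hydroxymethyl. None of them exchanges one donor-and-acceptor group for another of similar kind, which is what happens here. The shared core is untouched.

In this assay a step of a 1.3-fold higher number from compound 3 to compound 4 (0.12 log units; within the scatter) is expected, roughly within the scatter, with no firm direction. Compound 4 is therefore estimated at 250 nM, with a range from 80 nM to 800 nM.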

Compound 4, half-maximal inhibitory concentration: > 20000 nM
Compound 4 was reported as a limit; the forecaster's own chance of this, stated with the estimate: 5%; middle value at least 80-fold (1.90 log units) from the limit.
By their numbers in this assay, from the lowest: compound 2; then compound 3; then compound 1. At a limit, above all of these: compound 4.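

In this assay compound 4 gives > 20000 nM, which is a limit of the assay and not a number: the limit of > 20000 nM in this assay, at which 1 of the 4 values shown sits.

The step of an at least 100-fold higher number from compound 3 to compound 4 (2.02 log units; beyond the scatter) shows that this aromatic carbon, para to a large group, does not accept every group with the same hydrogen-bond count, since hydroxymethyl and carbamoyl each count one donor and one acceptor. The earlier compounds shown here had both oxygen-bearing groups far ahead of chloro, but carbamoyl also bears oxygen and goes against that pattern, with an at least 320-fold higher number from compound 2 to compound 4 (2.51 log units; beyond the scatter) and an at least 4.3-fold higher number from compound 1 to compound 4 (0.63 log units; beyond the scatter), so this replacement leaves the compound behind even the chloro compound in this assay.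

The compounds shown leave open whether this loss goes with the carbonyl or with the nitrogen of carbamoyl, a question on which a methyl ester, an acetyl group or an aminomethyl group at the same carbon would bear. Also open, from the compounds shown here alone, is whether a carboxylic acid here would behave like carbamoyl or like hydroxy, and whether a longer chain would change the outcome of this replacement.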